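The compounds below may be only part of what the source reports. "The series", "measured", "known", "first", "only" and "open" are said of these compounds alone.

Measured so far in a physicochemical assay for solubility, read by HPLC, in phosphate buffer, measured as kinetic solubility, at pH 7.4; a lower number here means a less soluble compound, a higher number a more soluble compound
- compound 1 `Cc1ccc(-c2ccc(Cl)cc2)n1-c1ccc(S(N)(=O)=O)cc1` gives 6100 nM
- compound 2 `CCC(=O)c1cc(-c2ccc(Cl)cc2)n(-c2ccc(S(N)(=O)=O)cc2)c1` gives 19500 nM
- compound 3 `CCC(=O)c1cc(-c2ccc(S(N)(=O)=O)cc2)n(-c2ccc(Cl)cc2)n1` gives 41900 nM

Within the data shown here, of these three numbers, the one for compound 3 at 41900 nM is the highest. The gap down to compound 2 at 19500 nM lies beyond the usual scatter, and the gap down to compound 1 at 6100 nM is wider still.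

The next compound, compound 4 `NS(=O)(=O)c1ccc(-c2cc(C(=O)C3CCC3)nn2-c2ccc(Cl)cc2)cc1` in the same notation, differs from compound 3 in one group only (cyclobutyl in place of ethyl on a carbonyl carbon). In words, cyclobutyl stands in place of ethyl on a carbonyl carbon, so propanoyl gives way to cyclobutylcarbonyl.

Among the measured compounds shown here, no two measured compounds differ in just one place, so nothing here shows this change directly and any expectation stays loose. A modest move to a lower number in this assay is expected, probably just beyond the scatter, though a step within it would be no surprise. Compound 3 at 41900 nM sits at the top of the measured numbers, which leaves more room below it than above. The estimated move (a 2.1-fold lower number from compound 3 to compound 4 (0.32 log units; beyond the scatter)) is of that modest size. For compound 4 the estimated value is 20000 nM with an expected range from 8000 nM to 45000 nM on this reading.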

Compound 4, solubility: 17200 nM
Compound 4: middle estimate off by 1.2-fold (0.07 log units), on the high side; measured number inside the range.
By their numbers in this assay, from the lowest: compound 1; then compounds 4 and 2 (each within the scatter of the next); then compound 3.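

In this assay, among these compounds, this pair gives the first direct reading of a single change: a 2.4-fold lower number from compound 3 to compound 4 (0.39 log units; beyond the scatter), a modest step that comes with cyclobutyl in place of ethyl on a carbonyl carbon. It shows that the number responds to what sits at this place, since going from propanoyl to cyclobutylcarbonyl moves it beyond the usual scatter, even though the change adds only carbon, including one four-membered non-aromatic ring, with no hydrogen-bond donors or acceptors and no net charge on either side. No measurement at hand accounts for the step, so it stands as an observation about this one pair, with no cause attached.

A single step cannot tell whether the ring itself or simply the larger carbon group goes with the lower number, and a straight butyl chain on the same carbonyl carbon would help to separate the two. On these data alone, how this assay would respond to a different kind of group here, such as an amine or a carboxylic acid, also stays open.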